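This account rests on a few compounds, and the source may have more. Where it says the series, first, only, none or still open, it means among the compounds named here.

Of the compounds shown here, three of one shared core have been measured in a functional assay on A549 cells (Homo sapiens) for antiproliferative activity, with a stated time of 48 h; on this read-out lower numbers stand for stronger inhibition of growth and higher numbers for weaker inhibition of growth. Compound 1 `Cc1cc(O)c(C2=NN(c3ccc(S(N)(=O)=O)cc3)C(c3ccccc3O)C2)cc1Cl` gives 15500 nM. Compound 2 `Cc1cc(O)c(C2=NN(c3ccc(S(N)(=O)=O)cc3)C(c3ccccc3Cl)C2)cc1Cl` gives 19300 nM, and compound 3 `Cc1cc(O)c(C2=NN(c3ccc(S(N)(=O)=O)cc3)C(/C=C/c3ccccc3)C2)cc1Cl` gives 30800 nM. Compound 2 stands second highest of the three numbers: its nearest neighbour is compound 1, with a 1.2-fold higher number from compound 1 to compound 2 (0.10 log units; within the scatter), and its furthest is compound 3, with a 1.6-fold higher number from compound 2 to compound 3 (0.20 log units; within the scatter). The remaining pair shows a 2.0-fold higher number from compound 1 to compound 3 (0.30 log units; within the scatter). None of the three steps leaves the scatter.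

Compound 4 `COc1ccc(C2CC(c3cc(Cl)c(C)cc3O)=NN2c2ccc(S(N)(=O)=O)cc2)cc1OC` is not yet measured. Relative to compound 2 the change is 3,4-dimethoxyphenyl in place of 2-chlorophenyl on a saturated ring carbon. The measured steps that bear on this are the two that also exchange the group on the same saturated ring carbon, a 2.0-fold higher number from compound 1 to compound 3 (0.30 log units; within the scatter) and a 1.6-fold higher number from compound 2 to compound 3 (0.20 log units; within the scatter), together with a 1.2-fold higher number from compound 1 to compound 2 (0.10 log units; within the scatter), which exchanges only a substituent on that ring. All of them stay within the scatter, and the data give no step beyond the scatter for any change at this position. The expectation for compound 4 is therefore no step beyond the scatter in this assay, which is written as a 1.0-fold lower number from compound 2 to compound 4 (0.01 log units; within the scatter). Compound 4 is accordingly estimated at 19000 nM, with a range from 8000 nM to 45000 nM.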

Compound 4, concentration for total growth inhibition: 19700 nM
The estimate for compound 4 lay 1.0-fold (0.02 log units) below the measured number; measured number inside the range.
By their numbers in this assay, from the lowest: compounds 1, 2, 4 and 3 (each within the scatter of the next).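

In this assay, 3,4-dimethoxyphenyl on the saturated ring carbon in place of 2-chlorophenyl gives a 1.0-fold higher number from compound 2 to compound 4 (0.01 log units; within the scatter), although a group of 10 heavy atoms with 2 hydrogen-bond acceptors enters for one of 7 heavy atoms with 0. The exchanges for the other two groups at this carbon, a 1.6-fold lower number from compound 3 to compound 4 (0.19 log units; within the scatter) and a 1.3-fold higher number from compound 1 to compound 4 (0.10 log units; within the scatter), also stay within the scatter. The earlier compounds shown here showed this tolerance only for 2-hydroxyphenyl, 2-chlorophenyl and 2-phenylethenyl, so it now extends, across these four compounds, to a phenyl group carrying two methoxy groups and to a group that counts hydrogen-bond acceptors. Nothing is available that would explain this flat picture at the position.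

The compounds shown leave open whether this tolerance holds for a group at this carbon that is neither a substituted phenyl nor 2-phenylethenyl, such as a primary amine, a carboxylic acid or a longer alkyl chain. They also leave open whether a change at the 4-sulfamoylphenyl group or the 5-chloro-2-hydroxy-4-methylphenyl group, which are the same in all four compounds, would give a step beyond the scatter.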